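The source may report more compounds than this note shows. Statements on the series, on what has been measured and on what is new or still open speak of the compounds shown alone.

In an in vitro ADME assay on microsomes from liver (Homo sapiens) for pharmacokinetics (a lower number here means slower removal, a higher number faster removal of the compound), compound 1 `CC(=O)N[C@@H](CCN1C[C@@H]2CN(C(=O)c3cccc(F)c3)C[C@@H]2C1)c1cccc(F)c1` gives 213 mL.min-1.g-1 and compound 2 `O=C(N[C@@H](CCN1C[C@@H]2CN(C(=O)c3cccc(F)c3)C[C@@H]2C1)c1cccc(F)c1)C1CCOC1` gives 331 mL.min-1.g-1, so these two stand within the scatter of each other. Compound 3 `CC(=O)N[C@@H](CCN1C[C@@H]2CN(C(=O)c3ccc(C(F)(F)F)cn3)C[C@@H]2C1)c1cccc(F)c1` departs from compound 1 at another carbonyl carbon: 5-(trifluoromethyl)pyridin-2-yl in place of 3-fluorophenyl on a carbonyl carbon. Going by the values given here, the only measured step, a 1.6-fold higher number from compound 1 to compound 2 (0.19 log units; within the scatter), replaces methyl elsewhere and does not test this change, so no measured step speaks to it directly. No shift beyond the scatter is therefore expected, and the estimated step is a 1.2-fold lower number from compound 1 to compound 3 (0.07 log units; within the scatter). For compound 3 the expected value is 180 mL.min-1.g-1, with an estimated range of 80 mL.min-1.g-1 to 380 mL.min-1.g-1.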

Compound 3, intrinsic clearance in microsomes: 152 mL.min-1.g-1
Compound 3: middle estimate off by 1.2-fold (0.07 log units), on the high side, within the range that was stated.
By their numbers in this assay, from the lowest: compounds 3, 1 and 2 (each within the scatter of the next, the first and the last beyond it).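

In this assay, going by these compounds alone, the earlier compounds differed only at the other carbonyl carbon, whereas 5-(trifluoromethyl)pyridin-2-yl in place of 3-fluorophenyl on the carbonyl carbon bonded to the amide-type ring nitrogen gives a 1.4-fold lower number from compound 1 to compound 3 (0.15 log units; within the scatter). This single pair therefore shows that this position accepts a ring with one hetero atom and more heavy atoms without a shift beyond the scatter. No supporting evidence bears on this result. From the compounds shown here alone, whether a carboxylic acid or an amine at this position would move the number beyond the scatter remains open, as does the outcome of combining oxolan-3-yl with 5-(trifluoromethyl)pyridin-2-yl.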